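The source may report more compounds than this note shows. Statements on the series, on what has been measured and on what is new or still open speak of the compounds shown alone.

Measured in an ADME assay on L6 cells (Rattus norvegicus) for cytotoxicity; a lower number here means a stronger inhibitor, a higher number a weaker inhibitor:
- Compound 1 `COc1cc2c(cc1C(C)NCCCc1ccccc1)C=CC(C)(C)O2`: 1080 nM
- Compound 2 `CC(NCc1ccccc1)c1cc2c(cc1O)OC(C)(C)C=C2`: 109000 nM

Of these two, compound 2 has the higher number. In this assay compound 2 stands at 109000 nM, which makes it the weaker inhibitor of the pair, and the gap to compound 1 lies well beyond the scatter of repeat measurements.

Still unmeasured is compound 3 `CC(NCCCc1ccccc1)c1cc2c(cc1O)OC(C)(C)C=C2`. It differs from compound 2 in one place, with phenethyl in place of phenyl on a saturated chain carbon bound to an amine nitrogen. Among the compounds with values here, no two measured compounds differ in just one place, so the data give no direct guide to the size of this step. What they do show is that compound 1, at 1080 nM, reaches a far lower number within this small set. Within the data shown here, a fall in this assay beyond the scatter is therefore expected, though this is a cautious guess from only two values. The estimated change is an 11-fold lower number from compound 2 to compound 3 (1.04 log units; beyond the scatter). For compound 3 the expected value is 10000 nM, with an estimated range from 2000 nM to 50000 nM.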

Compound 3, half-maximal inhibitory concentration: 27000 nM
Beside the measured number, compound 3's estimate is 2.7-fold (0.43 log units) below it, and the stated range covers the measured number.
By their numbers in this assay, from the lowest: compound 1; then compound 3; then compound 2.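

In this assay, within the data shown here, the step with phenethyl in place of phenyl on a saturated chain carbon bound to an amine nitrogen gives the first direct reading of this position: a 4.0-fold lower number from compound 2 to compound 3 (0.61 log units; beyond the scatter). The other step, with hydrogen in place of methyl on an oxygen on an aromatic ring, gives a 25-fold higher number from compound 1 to compound 3 (1.40 log units; beyond the scatter), so the change on that oxygen has the larger effect on the number of the two single changes read here. Nothing measured here explains why either change moves the number as it does.

From the compounds shown here alone, two steps cannot show how the number responds across a series, so it remains open whether a longer chain than phenethyl would lower it further or whether the trend would stop or reverse. Going by these compounds, it is also open whether an ethyl group on the oxygen would give a number closer to that of the methyl or the hydrogen, and whether a pyridine ring in place of the benzene ring at the chain end would preserve the step seen with phenethyl.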